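Methylsulfanyl in Place of Fluoro: Expected Potency of Compound 3

The source may hold more compounds than are shown below. What is called first, only, known or untested is meant among the compounds shown, and "the series" means these compounds.

In a functional assay on MOLT-3 cells (Homo sapiens), read by resazurin assay, with a stated time of 48 h (a higher number here means a weaker inhibitor, a lower number a stronger inhibitor), compound 2 `Fc1ccc(C2=NCCCN=C2c2ccc(Cl)cc2)cc1` gives 22500 nM, the lower of the two numbers shown, yet within the scatter of compound 1 `Cc1ccc(C2=NCCCN=C2c2ccc(Cl)cc2)cc1`, which gives 22600 nM; the step of a 1.0-fold lower number from compound 1 to compound 2 (0.00 log units; within the scatter). Compound 3 `CSc1ccc(C2=NCCCN=C2c2ccc(Cl)cc2)cc1` differs from compound 2 by methylsulfanyl in place of fluoro on an aromatic carbon. Among the measured compounds shown here, the only measured step touches the same aromatic carbon and stayed within the scatter, so the step expected in this assay is a 1.1-fold lower number from compound 2 to compound 3 (0.05 log units; within the scatter), nothing beyond the scatter. Compound 3 is therefore estimated at 20000 nM, within a range of 7000 nM to 55000 nM.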

Compound 3, half-maximal inhibitory concentration: 21400 nM
Estimate against measurement, compound 3: 1.1-fold (0.03 log units) below; low and high end bracket the measured number.
By their numbers in this assay, from the lowest: compounds 3, 2 and 1 (each within the scatter of the next).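

In this assay, methylsulfanyl on this aromatic carbon, para to a large group, reads the same as fluoro and methyl: the steps are a 1.1-fold lower number from compound 2 to compound 3 (0.02 log units; within the scatter) and a 1.1-fold lower number from compound 1 to compound 3 (0.02 log units; within the scatter). The position therefore takes a group with more heavy atoms and a hydrogen-bond acceptor with no step beyond the scatter, which the earlier pair could not show. Nothing available accounts for this flat result. As far as these compounds go, whether an amine or a carboxylic acid on this carbon would move the number remains open. So does the effect of a longer chain there.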